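A few compounds are considered here, and "the series" means these few. Any claim that something is new, unique, unknown or untested is made for them only; others in the source may bear on it.

Compound 1 `Nc1scc(CN2CCN(c3ccccc3C(F)(F)F)CC2)c1C(=O)c1ccc(Cl)cc1`: -60%
Compound 2 `Nc1scc(CN2CCN(c3cccc(Cl)c3)CC2)c1C(=O)c1ccc(Cl)cc1`: -77%

Both were tested in a functional assay on CHO cells with adenosine receptor A1 (Homo sapiens) as the target, read by cAMP accumulation and immunoassay, with a stated time of 6 min, tested at 10 uM; a lower number here means a stronger effect, a higher number a weaker effect of the compound at the concentration tested. Compound 2 holds the lowest number of the two; compound 1 sits higher, as the step of a number 17 percentage points lower from compound 1 to compound 2 (beyond the scatter) shows, a modest one. Compound 3 `Nc1scc(CN2CCN(c3ccccc3Cl)CC2)c1C(=O)c1ccc(Cl)cc1` differs from compound 2 by 2-chlorophenyl in place of 3-chlorophenyl on an amine nitrogen in a ring. Going by the values given here, the only measured step that bears on it is a number 17 percentage points lower from compound 1 to compound 2 (beyond the scatter), which also exchanged one substituted phenyl on that ring nitrogen for another. A step of similar, modest size is therefore expected, most likely back toward the number of compound 1, so compound 3 is estimated at -65% (range -82% to -45%), an expected step of a number 12 percentage points higher from compound 2 to compound 3 (beyond the scatter).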

Compound 3, a percentage reported as activity, at one concentration (the size of the read-out at that concentration, not a potency): -18%
The estimate for compound 3 lay 47 percentage points below the measured number; the measured number lies above the stated range.
By their numbers in this assay, from the lowest: compound 2; then compound 1; then compound 3.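

Moving the chloro alone, with the same atoms joined differently, gives a number 59 percentage points higher from compound 2 to compound 3 (beyond the scatter) and shows that in this assay the place of the chloro on this phenyl can matter far more than the earlier step revealed. Keeping that place on the phenyl, the exchange from 2-(trifluoromethyl)phenyl to 2-chlorophenyl gives a number 42 percentage points higher from compound 1 to compound 3 (beyond the scatter) and shows that the identity of the group there also counts. No measured evidence accounts for either step.

As far as these compounds go, whether a fluoro or methoxy group on this phenyl would read like compound 2 or compound 3 remains open. From the compounds shown here alone, how 3-(trifluoromethyl)phenyl would compare with compound 2 is equally open.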